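The source may hold more compounds than are shown below. What is called first, only, known or untested is meant among the compounds shown, and "the series" means these compounds.

Compound 1 `O=C(O)CCNC(=O)c1ccc(C(Oc2ccc(-n3cc(C(F)(F)F)cn3)cc2)C2CC2)cc1`: 15000 nM
Compound 2 `CCCC(Oc1ccc(-n2cc(C#N)cn2)cc1)c1ccc(C(=O)NCCC(=O)O)cc1`: > 50000 nM

Among the compounds with values here, in a functional assay on cells for antagonist activity at Glucagon receptor (Homo sapiens), read by cAMP accumulation, in the presence of a further agent that is not named here (a higher number here means a weaker inhibitor, a lower number a stronger inhibitor), compound 1 gives 15000 nM, the only actual number in this pair. Compound 2 reaches only a limit of the assay, sitting at the limit of > 50000 nM in this assay, at which 1 of the 2 values shown sits. Compound 3 `CCC(Oc1ccc(-n2cc(C(F)(F)F)cn2)cc1)c1ccc(C(=O)NCCC(=O)O)cc1` is not yet measured; it differs from compound 1 by ethyl in place of cyclopropyl on a saturated chain carbon bound to an aromatic carbon and an oxygen on an aromatic ring. Within the data shown here, no measured pair of compounds differing in one place exists here, so there is no measured guide for this change. The swap is expected to move the value little, not beyond the scatter, and the expected step from compound 1 to compound 3 is a 1.3-fold higher number from compound 1 to compound 3 (0.12 log units; within the scatter). Compound 3 is therefore estimated at 20000 nM, with a range of 6000 nM to 60000 nM.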

Compound 3, antagonist equilibrium constant: > 22000 nM
Compound 3 was reported as a limit; the forecaster's own chance of this, stated with the estimate: 25%; at least 1.1-fold (0.04 log units) between middle value and limit.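

This is the only one-place comparison shown at this position: at the saturated chain carbon bound to an aromatic carbon and an oxygen on an aromatic ring, ethyl in place of cyclopropyl gives an at least 1.4-fold higher number from compound 1 to compound 3 (0.16 log units; that floor lies within the scatter) in this assay. Compound 3 stands as a limit, not a number: the limit of > 22000 nM in this assay, at which 1 of the 3 values shown sits.

Ethyl therefore shows no gain over cyclopropyl, and whether the two truly differ cannot be read. Open, from the compounds shown here alone, is whether a cyclobutyl group or an amine at this carbon would give a measurable value.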